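One Substituent Swap on an Amide-Type Nitrogen

This account rests on a few compounds, and the source may have more. Where it says the series, first, only, none or still open, it means among the compounds named here.

Measured compounds:
compound 1 `Cc1ccc(NC(=O)Nc2cccc(CNc3nccnc3Cl)c2)cc1C`: 10700 nM
compound 2 `Cc1ccc(NC(=O)Nc2cccc(CNc3nccnc3Cl)c2)c(C)c1`: 9290 nM

In a functional assay on HepG2 cells (Homo sapiens) for antiproliferative activity, read by MTT assay, with a stated time of 48 h (on this read-out higher numbers stand for weaker inhibition and lower numbers for stronger inhibition), compound 1 gives 10700 nM, and compound 2 gives 9290 nM. For the measured compounds named here, the one measured step, a 1.2-fold lower number from compound 1 to compound 2 (0.06 log units; within the scatter), moves a methyl group from one ring position to another and is within the scatter, so compound 2 and compound 1 cannot be told apart on these numbers.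

Compound 3 `O=C(Nc1cccc(CNc2nccnc2Cl)c1)Nc1ccc(F)c(Cl)c1` shares the core of compound 2 and differs in one place: 3-chloro-4-fluorophenyl in place of 2,4-dimethylphenyl on an amide-type nitrogen. Going by the values given here, no measured step involves exchanging a dimethylphenyl for a halogenated phenyl, so nothing here points to a change beyond the scatter in either direction; the only guide is that compound 2 and compound 1 sit near each other. Compound 3 is therefore expected to give about 9000 nM, with a range from 3000 nM to 30000 nM, which means an estimated step of a 1.0-fold lower number from compound 2 to compound 3 (0.01 log units; within the scatter).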

Compound 3, half-maximal inhibitory concentration: 6750 nM
For compound 3 the middle estimate is 1.3-fold (0.12 log units) above the measured one, within the range that was stated.
By their numbers in this assay, from the lowest: compounds 3, 2 and 1 (each within the scatter of the next).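

In this assay, for the compounds shown here, the change to 3-chloro-4-fluorophenyl on the amide-type nitrogen gives a 1.4-fold lower number from compound 2 to compound 3 (0.14 log units; within the scatter) and a 1.6-fold lower number from compound 1 to compound 3 (0.20 log units; within the scatter) when it replaces either dimethylphenyl group, and these are the first steps here that exchange methyl groups for halogens instead of moving a methyl group. Even this change of atoms leaves all three compounds indistinguishable on these numbers, so the two methyl groups and the chlorine and fluorine pair cannot be told apart at this position. No measurement available here explains this result.

Still open, going by these compounds, is whether a different kind of group on this nitrogen, such as a phenyl ring carrying an amine or a carboxylic acid, or a longer alkyl chain, would move the number beyond the scatter. Also open, on these data alone, is what chlorine alone or fluorine alone would give on this ring.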